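The source may report more compounds than this note shows. Statements on the series, on what has been measured and on what is new or still open speak of the compounds shown alone.

For the measured compounds named here, compound 3 `CCN(CC)CCNC(=O)c1ccc(C(CC)(CC)c2ccc(OCS(=O)(=O)c3ccccc3)c(C)c2)n1CC` is the only member of this small set to give a number in a functional assay on BXPC-3 cells (Homo sapiens) for antiproliferative activity, read by MTT assay, with a stated time of 24 h; a higher number here means a weaker inhibitor, a lower number a stronger inhibitor: compound 3 gives 6270 nM. Compound 1 `CCn1c(C(=O)NCCC(=O)OC)ccc1C(CC)(CC)c1ccc(OCS(=O)(=O)c2ccccc2)c(C)c1` reaches only the limit of this assay, > 50000 nM. Compound 2 `CCn1c(C(=O)N[C@@H](CC(=O)OC)C(=O)OC)ccc1C(CC)(CC)c1ccc(OCS(=O)(=O)c2ccccc2)c(C)c1` likewise sits at the limit, > 50000 nM. Compound 4 `CCn1c(C(=O)N[C@H](C)C(=O)O)ccc1C(CC)(CC)c1ccc(OCS(=O)(=O)c2ccccc2)c(C)c1` differs from compound 3 by 1-carboxyethyl in place of 2-(diethylamino)ethyl on an amide-type nitrogen. Going by the values given here, the steps that bear on this are an at least 7.9-fold lower number from compound 1 to compound 3 (0.90 log units; beyond the scatter) and an at least 7.9-fold lower number from compound 2 to compound 3 (0.90 log units; beyond the scatter), each swapping a methoxycarbonyl-bearing chain for the diethylamino-bearing one, the only change that moved a value off the limit (the limit of > 50000 nM in this assay, at which 2 of the 3 values shown sit). Compound 4 gives up that diethylamino group in favour of 1-carboxyethyl, so a weakening step is expected, a 6.4-fold higher number from compound 3 to compound 4 (0.80 log units; beyond the scatter). Compound 4 is therefore estimated at 40000 nM, between 10000 nM and 100000 nM, with a real chance that only the limit is reported.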

Compound 4, half-maximal inhibitory concentration: 20100 nM
The estimate for compound 4 lay 2.0-fold (0.30 log units) above the measured number; the measured number falls inside the stated range.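

For the compounds shown here, at this amide-type nitrogen, 2-(diethylamino)ethyl is not the only group that gives a number in this assay, since 1-carboxyethyl does too, with an at least 2.4-fold lower number from compound 1 to compound 4 (0.39 log units; beyond the scatter) and an at least 2.4-fold lower number from compound 2 to compound 4 (0.39 log units; beyond the scatter). The diethylamino-bearing chain still holds the lower number, with a 3.2-fold higher number from compound 3 to compound 4 (0.51 log units; beyond the scatter). Only compound 1 and compound 2, with their methoxycarbonyl-bearing chains, stay at the limit: the limit of > 50000 nM in this assay, at which 2 of the 4 values shown sit.

The compounds shown leave open how a primary amine or a longer chain ending in a carboxylic acid would read on this nitrogen. They also leave open how the methyl ester of 1-carboxyethyl would compare with compound 4.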